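The compounds below may be only part of what the source reports. "The series", "measured", "known", "first", "only" and "open" are said of these compounds alone.

Measured so far in a functional assay on T47D cells (Homo sapiens) for cytotoxicity, read by MTT assay; a lower number here means a stronger inhibitor, a higher number a weaker inhibitor:
Compound 1 `O=C(/C=C/c1ccc(N2CCCC2)cc1)c1ccc(O)cc1`: 1370 nM
Compound 2 `O=C(/C=C/c1ccc(F)cc1)c1ccc(O)cc1O`: 8310 nM
Compound 3 `COc1cc(O)ccc1C(=O)/C=C/c1ccc(F)cc1`: > 25000 nM (a limit, not a number)

Compound 3 stands at the limit of > 25000 nM in this assay, at which 1 of the 3 values shown sits, so it has no number of its own. Compound 4 `O=C(/C=C/c1ccc(F)cc1)c1ccc(O)cc1` carries hydrogen in place of methoxy on an aromatic carbon. The nearest measured change is an at least 3.0-fold higher number from compound 2 to compound 3 (0.47 log units; beyond the scatter), with methyl in place of hydrogen on an oxygen at that same group. For the measured compounds named here, no measured step removes the group outright. Compound 1 also lacks it, but differs in a second place too. A step to a lower number is expected, of roughly that size, with its true size left open by the limit. The expected step is an at least 2.7-fold lower number from compound 3 to compound 4 (0.44 log units; beyond the scatter). For compound 4 the estimate is 9000 nM, with an expected range of 3000 nM to 25000 nM.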

Compound 4, half-maximal inhibitory concentration: 13800 nM
The estimate for compound 4 lay 1.5-fold (0.19 log units) below the measured number; the range from low to high includes it.
By their numbers in this assay, from the lowest: compound 1; then compounds 2 and 4 (each within the scatter of the next). At a limit, above all of these: compound 3.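

In this assay compound 3 remains a limit, not a number: the limit of > 25000 nM in this assay, at which 1 of the 4 values shown sits. Hydrogen in place of methoxy gives an at least 1.8-fold lower number from compound 3 to compound 4 (0.25 log units; that floor lies within the scatter), so methoxy is not firmly separated from hydrogen at this position, and hydrogen in place of hydroxy gives a 1.7-fold higher number from compound 2 to compound 4 (0.22 log units; within the scatter), so hydroxy is not separated from it either. The clear change lies elsewhere: fluoro in place of pyrrolidin-1-yl gives a 10-fold higher number from compound 1 to compound 4 (1.00 log units; beyond the scatter).

Open, going by these compounds, is how an amine or an ethoxy group would read at this position.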